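Second Aryl Group at the Central Carbon

The source may hold more compounds than are shown below. What is called first, only, known or untested is meant among the compounds shown, and "the series" means these compounds.

Compound 1, `Cc1nc(-c2ccc(Cl)cc2)c(CC(=O)O)s1`: 41000 nM
Compound 2, `CCC(c1ccccc1)c1nc(-c2ccc(Cl)cc2)c(CC(=O)O)s1`: > 100000 nM

In an in vitro functional assay on HEK285-7 cells for antagonist activity at prostaglandin D2 receptor 2 (Homo sapiens), read by BRET and beta-arrestin recruitment (a lower number here means a stronger inhibitor, a higher number a weaker inhibitor), compound 1 gives 41000 nM. Compound 2 reaches only (the limit of > 100000 nM in this assay, at which 1 of the 2 values shown sits), which is a limit of the assay and not a number, so compound 2 stands at the weak end of what this assay can read. Compound 3, `COc1ccc(C(c2ccccc2)c2nc(-c3ccc(Cl)cc3)c(CC(=O)O)s2)cc1`, differs from compound 2 by 4-methoxyphenyl in place of ethyl on a saturated chain carbon bound to two aromatic carbons. Within the data shown here, no measured step is available to anchor this change, so in this assay the expected shift is none beyond the usual scatter, with compound 3 likely remaining very weak. Compound 3 is expected near 80000 nM, within 15000 nM to 400000 nM. The expected step is an at least 1.2-fold lower number from compound 2 to compound 3 (0.09 log units; that floor lies within the scatter).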

Compound 3, half-maximal inhibitory concentration: 76 nM
Beside the measured number, compound 3's estimate is 1100-fold (3.02 log units) above it; measured number below the stated range.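

At this saturated chain carbon bound to two aromatic carbons, the group carried alongside the phenyl matters greatly: in this assay, 4-methoxyphenyl in place of ethyl gives an at least 1300-fold lower number from compound 2 to compound 3 (3.11 log units; beyond the scatter). Going by these compounds, the value of compound 2, > 100000 nM, is a limit of the assay and not a number, so the step's full size stays unknown. Compound 3 is the only compound shown with two aromatic rings on this carbon.

On these data alone, whether the ring or its methoxy carries the change stays open. So does whether a plain phenyl or a 4-hydroxyphenyl would hold this strength.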